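This account rests on a few compounds, and the source may have more. Where it says the series, first, only, none or still open, it means among the compounds named here.

In a functional assay on HGC-27 cells (Homo sapiens) for inhibition, read by MTT assay, with a stated time of 72 h (on this read-out lower numbers stand for stronger inhibition and higher numbers for weaker inhibition), compound 2 `Cc1cc(N2CC[C@@H](C)[C@@H](N(C)c3ncnc4[nH]ccc34)C2)n2nc(SCc3ccccc3Br)nc2n1` gives 21300 nM. Compound 3 `Cc1ccc(CSc2nc3nc(C)cc(N4CC[C@@H](C)[C@@H](N(C)c5ncnc6[nH]ccc56)C4)n3n2)cc1` gives 15200 nM in this assay, a step of a 1.4-fold lower number from compound 2 to compound 3 (0.15 log units; within the scatter). Compound 1 `Cc1cc(N2CC[C@@H](C)[C@@H](N(C)c3ncnc4[nH]ccc34)C2)n2nc(SCc3nc4ccccc4[nH]3)nc2n1` reaches only a limit of this assay, > 100000 nM. Of the two numbers shown, compound 2 stands highest, with compound 3 nearest. Compound 4 `CCCSc1nc2nc(C)cc(N3CC[C@@H](C)[C@@H](N(C)c4ncnc5[nH]ccc45)C3)n2n1` awaits measurement; it differs from compound 2 by ethyl in place of 2-bromophenyl on a saturated chain carbon bound to a sulfur. The measured steps of an at least 4.6-fold lower number from compound 1 to compound 2 (0.67 log units; beyond the scatter) and an at least 6.5-fold lower number from compound 1 to compound 3 (0.81 log units; beyond the scatter) concern the benzimidazolyl replacement, and the step of a 1.4-fold lower number from compound 2 to compound 3 (0.15 log units; within the scatter) exchanges one aryl for another; none covers an ethyl. The expected step is therefore a 1.9-fold higher number from compound 2 to compound 4 (0.27 log units; within the scatter), a modest rise. For compound 4 the estimate is 40000 nM, between 10000 nM and 150000 nM.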

Compound 4, half-maximal inhibitory concentration: 20900 nM
For compound 4 the middle estimate is 1.9-fold (0.28 log units) above the measured one; the measured number falls inside the stated range.
By their numbers in this assay, from the lowest: compounds 3, 4 and 2 (each within the scatter of the next). At a limit, above all of these: compound 1.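

In this assay, this position does not need an aromatic ring to hold the level of compounds 2 and 3: ethyl in place of 2-bromophenyl gives a 1.0-fold lower number from compound 2 to compound 4 (0.01 log units; within the scatter), and ethyl in place of 4-methylphenyl gives a 1.4-fold higher number from compound 3 to compound 4 (0.14 log units; within the scatter). A small chain and two different aryl groups on this saturated chain carbon bound to a sulfur thus cannot be told apart. Only the 1H-benzimidazol-2-yl of compound 1 stands apart, with an at least 4.7-fold lower number from compound 1 to compound 4 (0.67 log units; beyond the scatter), and this step starts from a limit, not a number: the limit of > 100000 nM in this assay, at which 1 of the 4 values shown sits.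

From the compounds shown here alone, whether an amine, a carboxylic acid or a longer chain in this place would give a number beyond the scatter of compounds 2, 3 and 4 stays open.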